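From 4-fluorophenyl to 2-fluorophenyl on the shared core

The source may report more compounds than this note shows. Statements on the series, on what has been measured and on what is new or still open speak of the compounds shown alone.

In a functional assay on CaEs17 cells (Homo sapiens) for cytotoxicity, read by MTT assay, with a stated time of 72 h (on this read-out higher numbers stand for weaker inhibition and lower numbers for stronger inhibition), compound 1 `C=C1C(=O)[C@@]23C(=O)OC[C@]4(C(=O)CCC(C)(C)[C@H]4C=O)[C@@H]2CC[C@@H]1[C@H]3O` gives 5850 nM. Compound 2 `C=C1C(=O)[C@@]23C(=O)OC[C@]4(C(=O)CCC(C)(C)[C@H]4C=O)[C@@H]2CC[C@@H]1[C@H]3OC(=O)c1ccc(C)cc1` carries (4-methylphenyl)carbonyl in place of hydrogen on an oxygen and gives 1050 nM. That change amounts to a 5.6-fold lower number from compound 1 to compound 2 (0.75 log units; beyond the scatter). Compound 3 `C=C1C(=O)[C@@]23C(=O)OC[C@]4(C(=O)CCC(C)(C)[C@H]4C=O)[C@@H]2CC[C@@H]1[C@H]3OC(=O)c1ccc(F)cc1` carries (4-fluorophenyl)carbonyl on the same oxygen and gives 8310 nM. This stands as a 1.4-fold higher number from compound 1 to compound 3 (0.15 log units; within the scatter), so the ester and the parent cannot be told apart here. Against the methyl analogue the picture differs, with a 7.9-fold higher number from compound 2 to compound 3 (0.90 log units; beyond the scatter).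

Compound 4 `C=C1C(=O)[C@@]23C(=O)OC[C@]4(C(=O)CCC(C)(C)[C@H]4C=O)[C@@H]2CC[C@@H]1[C@H]3OC(=O)c1ccccc1F` has the same atoms joined differently: 2-fluorophenyl in place of 4-fluorophenyl on a carbonyl carbon. It has 2-fluorophenyl in place of 4-fluorophenyl on a carbonyl carbon. Among the compounds with values here, no measured step moves a fluoro group around the ring, so none bears on this change directly. The closest evidence is a 7.9-fold higher number from compound 2 to compound 3 (0.90 log units; beyond the scatter), which shows that one edit on the aromatic ring can register in this small set, and that argues for a wide range. With compound 3 so close to compound 1, an estimated 1.4-fold lower number from compound 3 to compound 4 (0.14 log units; within the scatter) is expected, with no firm direction. In this assay the estimate for compound 4 is 6000 nM, expected to fall between 2000 nM and 16000 nM.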

Compound 4, half-maximal inhibitory concentration: 8550 nM
Beside the measured number, compound 4's estimate is 1.4-fold (0.15 log units) below it; the range from low to high includes it.
By their numbers in this assay, from the lowest: compound 2; then compounds 1, 3 and 4 (each within the scatter of the next).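

In this assay, within the data shown here, the fluoro group's two placements, 4-fluorophenyl and 2-fluorophenyl on a carbonyl carbon, cannot be told apart, with a 1.0-fold higher number from compound 3 to compound 4 (0.01 log units; within the scatter) in this pair, something the earlier compounds could not show with only one fluorinated ester among them. The new ester also stays level with the unacylated parent, at a 1.5-fold higher number from compound 1 to compound 4 (0.16 log units; within the scatter), yet remains clearly separated from the methyl-bearing ester, at an 8.1-fold higher number from compound 2 to compound 4 (0.91 log units; beyond the scatter), so among the esters shown only the 4-methylphenyl ester stands apart from the parent, while both fluorinated esters do not. Nothing available here speaks to the reason for this pattern.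

The compounds shown leave open whether the gain belongs to the methyl group itself, since only one ester separates from the parent and a single example cannot define a trend at this position. A chloro, ethyl or amino group in place of the methyl of 4-methylphenyl would test that, and an ester carrying a longer chain instead of an aromatic ring would show whether the aromatic ring is needed at all.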